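Working notes: partition coefficients across a three-compound set

The source may report more compounds than this note shows. Statements on the series, on what has been measured and on what is new or still open speak of the compounds shown alone.

Measured so far:
compound 1, `Cc1nc2ccccc2c(=O)n1/N=C/c1ccc(Oc2ccc3ccccc3c2)cc1`: 5.22 in a physicochemical assay for lipophilicity, in phosphate buffer, measured as octanol-water partition; on this read-out lower numbers stand for lower lipophilicity and higher numbers for higher lipophilicity
compound 2, `CCCc1nc2ccccc2c(=O)n1/N=C/c1ccc(Oc2ccc3ccccc3c2)cc1`: 6.12 in this assay

Within the data shown here, compound 2 stands highest of the two numbers measured in this assay, with compound 1 as its only neighbour. Among the measured compounds shown here, the one measured step, a number 0.90 log units higher from compound 1 to compound 2 (beyond the scatter), is the sole piece of internal calibration and it concerns the saturated chain on the core, not the aryl ether end of the molecule.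

Compound 3, `CCCc1nc2ccccc2c(=O)n1/N=C/c1ccc(Oc2ccccc2)cc1`, is not yet measured. Relative to compound 2 the change is phenyl in place of naphthalen-2-yl on an oxygen on an aromatic ring. For the measured compounds named here, no measured pair covers this kind of change, so the step from compound 1 to compound 2 bears on it only as a reminder of how much the read-out moves; it gives no direct guide to size or direction here.

The expected step from compound 2 to compound 3 in this assay is a number 1.17 log units lower from compound 2 to compound 3 (beyond the scatter), a decrease beyond the scatter. Compound 3 is therefore estimated at 4.95, with a range from 4.5 to 5.4.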

Compound 3, partition coefficient: 5.2
Estimate against measurement, compound 3: 0.25 log units below, and the stated range covers the measured number.
By their numbers in this assay, from the lowest: compounds 3 and 1 (each within the scatter of the next); then compound 2.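

In this assay, the read-out responds at the aryl ether end of the molecule as well as at the saturated chain on the core: phenyl in place of naphthalen-2-yl on an oxygen on an aromatic ring gives a number 0.92 log units lower from compound 2 to compound 3 (beyond the scatter). Among these compounds, the earlier step, a number 0.90 log units higher from compound 1 to compound 2 (beyond the scatter), concerned only the chain, so this is the first measured change at this position, and it runs in the opposite direction with a similar printed size. No separate measurement bears on why the number falls with this change.

The compounds shown leave open whether phenyl in place of naphthalen-2-yl would give a step of similar size in the series member carrying the chain of compound 1, since only the chain of compound 2 has been paired with this change. They also leave open how the read-out would respond to a group of a different kind at this end of the molecule, such as an amine or a carboxylic acid on the phenyl ring.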